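This account rests on a few compounds, and the source may have more. Where it says the series, first, only, none or still open, it means among the compounds named here.

Three compounds built on one shared core were tested in an assay on isolated protein (strain Sprague-Dawley) for inhibition of Amine oxidase [flavin-containing] A (Rattus norvegicus), read by spectrophotometry, with a stated time of 5 min, tested at 10 uM; on this read-out higher numbers stand for more inhibition at the one concentration tested (going by the name of the read-out) and lower numbers for less inhibition. Compound 1 `CCOC(=O)COc1cc(=O)oc2cc(OCc3cccc(Cl)c3)ccc12` gives 0% in this assay. Compound 2 `O=C(O)COc1cc(=O)oc2cc(OCc3cccc(Cl)c3)ccc12` gives 0% in this assay. Compound 3 `CCOC(=O)c1cc(=O)oc2cc(OCc3cccc(Cl)c3)ccc12` gives 4.4% in this assay. All three numbers lie within the usual scatter of one another, so none of the three can be said to differ from the others.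

Compound 2 differs from compound 1 by a single change (hydrogen in place of ethyl on an oxygen next to a carbonyl group). That change made a step of no change at the digits printed from compound 1 to compound 2 (within the scatter).

Compound 3 differs from compound 1 in its core (ethoxycarbonyl in place of (ethoxycarbonyl)methoxy on an aromatic carbon).

Compound 4 `O=C(O)c1cc(=O)oc2cc(OCc3cccc(Cl)c3)ccc12` has not yet been measured. Among the compounds with values here, it differs from compound 3 by hydrogen in place of ethyl on an oxygen next to a carbonyl group, which is the same change, at the same place, as the one that turned compound 1 into compound 2. The step from compound 3 to compound 4 is expected to be a number 1.4 percentage points lower from compound 3 to compound 4 (within the scatter), because the same change made a step of no change at the digits printed from compound 1 to compound 2 (within the scatter) and compound 3 gave 4.4%. Compound 4 is thus estimated to give about 3%, most likely somewhere between -5% and 12%.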

Compound 4, a percentage reported as inhibition, at one concentration (the size of the read-out at that concentration, not a potency): 0%
Estimate against measurement, compound 4: 3 percentage points above; low and high end bracket the measured number.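

Replacing ethyl with hydrogen on an oxygen next to a carbonyl group gives a number 4.4 percentage points lower from compound 3 to compound 4 (within the scatter); carboxy in place of carboxymethoxy gives no change at the digits printed from compound 2 to compound 4 (within the scatter), and carboxy in place of (ethoxycarbonyl)methoxy gives no change at the digits printed from compound 1 to compound 4 (within the scatter). In this assay, the swap of ethyl for hydrogen therefore carries from one core to the other with no difference that can be told from the noise: the same change on two cores in this assay, no change at the digits printed (within the scatter) from compound 1 to compound 2 and a number 4.4 percentage points lower (within the scatter) from compound 3 to compound 4, 4.4 percentage points apart, within the scatter of two such steps. Within the data shown here, this agreement is weak evidence, though: all four numbers sit close to nothing, so it shows only that the change brings no clear inhibition at the one concentration tested on these two cores, and not how it would act on a compound that inhibits the enzyme clearly.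

The compounds shown leave open what an amide or a longer chain in place of the carboxy of compound 4 would do. They also leave open whether any group at that place can lift inhibition clear of the scatter.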